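One Substituent Exchanged on a Shared Core

The source may report more compounds than this note shows. Statements on the series, on what has been measured and on what is new or still open speak of the compounds shown alone.

In a physicochemical assay for solubility, read by LC-MS, in phosphate buffer, with a stated time of 24 h, at pH 7.4 (on this read-out lower numbers stand for lower solubility and higher numbers for higher solubility), compound 1 `CN(c1ncco1)c1cnc(NCc2c(F)ccc3c2CCO3)n2cnnc12` gives 67000 nM and stands highest of the two measured numbers, while compound 2 `Cc1nccn1-c1cnc(NCc2c(F)ccc3c2CCO3)c2cn[nH]c(=O)c12` gives 7000 nM as the lower one, a gap beyond the scatter. Compound 3 `C[C@@H]1CC(=O)N(c2cnc(NCc3c(F)ccc4c3CCO4)n3cnnc23)C1` awaits measurement. It has 4-methyl-2-oxopyrrolidin-1-yl in place of methyl(1,3-oxazol-2-yl)amino on an aromatic carbon of the core of compound 1. Among the measured compounds shown here, no measured pair shows this exchange, so in this assay only a small downward move is expected, none beyond the scatter. The estimated step is a 1.5-fold lower number from compound 1 to compound 3 (0.17 log units; within the scatter) at the middle of the range. For compound 3 the expected value is 45000 nM (estimated range 12000 nM to 130000 nM).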

Compound 3, solubility: 130000 nM
Beside the measured number, compound 3's estimate is 2.9-fold (0.46 log units) below it; the measured number falls inside the stated range.
By their numbers in this assay, from the lowest: compound 2; then compounds 1 and 3 (each within the scatter of the next).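

In this assay the exchange of methyl(1,3-oxazol-2-yl)amino for 4-methyl-2-oxopyrrolidin-1-yl on this aromatic carbon gives a 1.9-fold higher number from compound 1 to compound 3 (0.29 log units; within the scatter) on the shared core, the first single exchange read at this position. A five-membered non-aromatic ring with one defined stereocentre thus takes the place of a five-membered aromatic ring without a step beyond the scatter. Nothing at hand explains this reading. Still open, as far as these compounds go, is whether the other arrangement at that stereocentre would read the same, and how a primary amine or a carboxylic acid on this carbon would compare.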